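This account rests on a few compounds, and the source may have more. Where it says the series, first, only, none or still open, it means among the compounds named here.

Of the compounds shown here, three have so far been tested in an ADME assay on cells (Homo sapiens) for cytotoxicity (a lower number here means that less compound is tolerated, a higher number that more compound is tolerated), and none of them yielded a number. Compound 1 `CCCc1nc(-c2ccc(OCCC(C)CCN3CCN(c4ccncc4)C3=O)cc2)no1` reaches only a limit of the assay, > 12500 nM. Compound 2 `O=C1N(CCC(CCOc2ccc(-c3ccc(Cl)cc3)cc2)Cc2ccccc2)CCN1c1ccncc1` likewise stops at a limit, > 10000 nM. Compound 3 `CC(CCCCN1CCN(c2ccncc2)C1=O)Oc1ccc(-c2ccc(Cl)cc2)cc1` also sits at a limit, > 12500 nM. Compound 1 therefore stands at the limit of > 12500 nM in this assay, at which 2 of the 3 values shown sit, and nothing sets it apart from the other two compounds, since compound 2 stands at the limit of > 10000 nM in this assay, at which 1 of the 3 values shown sits, which is the same kind of ceiling. For the measured compounds named here, no step between two measured compounds that differ in a single place is available, so no measured change can be drawn on.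

Compound 4 `Cc1nc(-c2ccc(OCCC(C)CCN3CCN(c4ccncc4)C3=O)cc2)no1` differs from compound 1 in one place: hydrogen in place of ethyl on a saturated chain carbon bound to an aromatic carbon, in words hydrogen in place of ethyl on a saturated chain carbon bound to an aromatic carbon. With every measured compound sitting at a limit, the step of a number no higher from compound 1 to compound 4 (the limit leaves the size open) is expected to be none beyond the scatter, with compound 4 most likely reported as a limit as well in this assay. Compound 4 is accordingly estimated at 12500 nM, with a range from 8000 nM to 20000 nM.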

Compound 4, half-maximal cytotoxic concentration: > 6250 nM
Compound 4 gave a limit, no number (the forecaster's own chance of this, stated with the estimate: 85%); the middle value lies beyond the limit too.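

Compound 1 and compound 4 both stand at limits of the assay in this assay, and the step between them cannot be read. The compounds shown leave open where the half-maximal cytotoxic concentration of any of them actually lies, and whether going from propyl to methyl changes it at all.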